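A few compounds are considered here, and "the series" means these few. Any claim that something is new, unique, unknown or untested is made for them only; others in the source may bear on it.

In a functional assay on HeLa cells (Homo sapiens) for inhibition, read by MTT assay, with a stated time of 72 h (a lower number here means a stronger inhibitor, a higher number a weaker inhibitor), three compounds that share one core and differ in a single group have numbers. Compound 1 `O=[N+]([O-])c1ccc(-c2nnc(SCCCN3CCN(c4nc5ccccc5s4)CC3)o2)cc1` carries nitro and gives 97800 nM in this test. Compound 2 `Clc1ccc(-c2nnc(SCCCN3CCN(c4nc5ccccc5s4)CC3)o2)cc1` carries chloro and gives 177000 nM in the same test. Compound 3 `Oc1ccc(-c2nnc(SCCCN3CCN(c4nc5ccccc5s4)CC3)o2)cc1` carries hydroxy and gives 139000 nM as its value. Compound 3 cannot be ranked against the other two, since a 1.4-fold higher number from compound 1 to compound 3 (0.15 log units; within the scatter) and a 1.3-fold lower number from compound 2 to compound 3 (0.10 log units; within the scatter) are both small. The remaining pair tells the same story, with a 1.8-fold higher number from compound 1 to compound 2 (0.26 log units; within the scatter) as its step.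

Compound 4 `c1ccc(-c2nnc(SCCCN3CCN(c4nc5ccccc5s4)CC3)o2)cc1` is compound 3 with hydrogen in place of hydroxy on an aromatic carbon so that 4-hydroxyphenyl becomes phenyl. Going by the values given here, no measured compound has hydrogen at this place, so the estimate is an extrapolation. The closest evidence is the three swaps above, which are exchanges at the same place on the ring, and none of them moved the number beyond the scatter. A step of similar small size is therefore expected, with no clear direction. The expected step is a 1.0-fold lower number from compound 3 to compound 4 (0.01 log units; within the scatter) and would lie within the scatter. For compound 4 the estimated value is 135000 nM with an expected range (65000 nM to 270000 nM).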

Compound 4, half-maximal inhibitory concentration: 229000 nM
Estimate against measurement, compound 4: 1.7-fold (0.23 log units) below, within the range that was stated.
By their numbers in this assay, from the lowest: compounds 1, 3, 2 and 4 (each within the scatter of the next, the first and the last beyond it).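

The bare ring adds the one reference point the earlier swaps lacked: compound 4 has only hydrogen at this position on the aromatic ring, so it shows what having no group there does in this assay. Taking away hydroxy gives a 1.6-fold higher number from compound 3 to compound 4 (0.22 log units; within the scatter) and taking away chloro gives a 1.3-fold higher number from compound 2 to compound 4 (0.11 log units; within the scatter), so neither group can be told apart from having no group at all, while replacing nitro with hydrogen gives a 2.3-fold higher number from compound 1 to compound 4 (0.37 log units; beyond the scatter), the first step in this series to clear the scatter, though only modestly. No measurement at hand explains this single separation, and it rests on one pair, since nitro remains within the scatter of both chloro and hydroxy.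

Going by these compounds, it remains open whether other groups at this position, such as an amine, a carboxylic acid or methoxy, would widen the modest gap seen with nitro or leave the number within the same narrow band. Also open, on these data alone, is whether a change elsewhere in the molecule, such as a longer chain in place of the one carrying the sulfur, would shift the number more than any of these ring swaps.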